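Replacing a sulfamoylphenyl group with a difluorophenyl group

The source may hold more compounds than are shown below. What is called first, only, known or untested is meant among the compounds shown, and "the series" means these compounds.

Three amides sharing one core have been tested in an ADME assay on LLC-MK2 cells (Macaca mulatta) for cytotoxicity, read by spectrophotometry and crystal violet staining, with a stated time of 4 days; a higher number here means that more compound is tolerated, a lower number that less compound is tolerated. Compound 1 `CC(C)n1ncc2c(C(=O)Nc3c(F)cccc3F)cc(-c3cccs3)nc21` reads > 200000 nM, which is a limit of the assay and not a number. Compound 2 `CC(C)n1ncc2c(C(=O)Nc3cccc(F)c3)cc(-c3cccs3)nc21` reads > 200000 nM, which is also a limit. For the measured compounds named here, compound 3 `CC(C)n1ncc2c(C(=O)Nc3cccc(S(N)(=O)=O)c3)cc(-c3cccs3)nc21` gives 25000 nM, the only true number of the three.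

Compound 4 `CC(C)n1ncc2c(C(=O)Nc3cccc(F)c3F)cc(-c3cccs3)nc21` is still unmeasured. It differs from compound 3 on an amide-type nitrogen, where 2,3-difluorophenyl stands in place of 3-sulfamoylphenyl: 2,3-difluorophenyl in place of 3-sulfamoylphenyl on an amide-type nitrogen.

Going by the values given here, two measured steps bear on this change: an at least 8.0-fold lower number from compound 1 to compound 3 (0.90 log units; beyond the scatter) and an at least 8.0-fold lower number from compound 2 to compound 3 (0.90 log units; beyond the scatter). Both lie beyond the scatter. Compound 4 shares with compound 1 and compound 2 the absence of the 3-sulfamoylphenyl, so an at least 8.0-fold lower number from compound 2 to compound 3 (0.90 log units; beyond the scatter) points to an expected step of similar size in the opposite direction in this assay, and a limit reading is likely. The estimated change is an 8.0-fold higher number from compound 3 to compound 4 (0.90 log units; beyond the scatter). For compound 4 the estimate is 200000 nM, with an expected range from 80000 nM to 400000 nM.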

Compound 4, half-maximal cytotoxic concentration: 75000 nM
For compound 4 the middle estimate is 2.7-fold (0.43 log units) above the measured one; measured number below the stated range.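

In this assay, for the compounds shown here, compound 4 shows that swapping out the 3-sulfamoylphenyl group raises the number, a 3.0-fold higher number from compound 3 to compound 4 (0.48 log units; beyond the scatter), yet it is the first compound without that group to give a true number instead of a limit. The sulfamoyl group is therefore not the only feature that matters at this position, since the fluorine pattern on the phenyl ring also changes the reading, with an at least 2.6-fold lower number from compound 2 to compound 4 (0.42 log units; beyond the scatter) and an at least 2.6-fold lower number from compound 1 to compound 4 (0.42 log units; beyond the scatter). These last two steps give only a minimum size, because compound 1 and compound 2 each read as a limit and not as a number: the limit of > 200000 nM in this assay, at which 2 of the 4 values shown sit.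

From the compounds shown here alone, how a phenyl ring carrying an amine or a carboxylic acid would read in this assay stays open. So does whether 2,3-difluorophenyl would give a similar reading on a different core.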